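A few compounds are considered here, and "the series" means these few. Any claim that something is new, unique, unknown or untested is made for them only; others in the source may bear on it.

Compound 1 `COC(=O)CC1CCN(C[C@H]2CN(c3ccc(-n4cc(-c5ccccn5)cn4)c(F)c3)C(=O)O2)CC1` gives 224 ug/mL in an ADME assay on HEK293-A cells (Homo sapiens) for cytotoxicity, read by MTT assay, with a stated time of 48 h; on this read-out lower numbers stand for stronger inhibition and higher numbers for weaker inhibition. Compound 2 `O=C1O[C@@H](CN2CCC(c3ccc(F)cc3)CC2)CN1c1ccc(-n2cc(-c3ccccn3)cn2)c(F)c1` reaches only the limit of this assay, reported as > 400 ug/mL. Compound 3 `O=C1CCC(=O)N1C[C@H]1CN(c2ccc(-n3cc(-c4ccccn4)cn3)c(F)c2)C(=O)O1` likewise returns only a limit in this assay, reported as > 400 ug/mL. Compound 3 therefore stands at the upper edge of what this study shows, together with one other compound, as the limit of > 400 ug/mL in this assay, at which 2 of the 3 values shown sit, records. Compound 4 `O=C1O[C@@H](Cn2ccnn2)CN1c1ccc(-n2cc(-c3ccccn3)cn2)c(F)c1` differs from compound 3 by 1H-1,2,3-triazol-1-yl in place of 2,5-dioxopyrrolidin-1-yl on a saturated chain carbon bound to a saturated ring carbon. Two measured steps start from compound 1, and both end at a limit: an at least 1.7-fold higher number from compound 1 to compound 2 (0.25 log units; that floor lies within the scatter) and an at least 1.7-fold higher number from compound 1 to compound 3 (0.25 log units; that floor lies within the scatter). Neither involves the triazole, and neither floor exceeds the scatter, so they give no direction for the present change. The expected outcome in this assay for compound 4 is therefore no step beyond the scatter, expressed as a number no higher from compound 3 to compound 4 (the limit leaves the size open). Compound 4 is expected to give 400 ug/mL, with a range from 200 ug/mL to 800 ug/mL, most likely reported again as a limit rather than a number.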

Compound 4, half-maximal inhibitory concentration: 225 ug/mL
For compound 4 the middle estimate is 1.8-fold (0.25 log units) above the measured one; the range from low to high includes it.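

Unlike compound 2 and compound 3, compound 4 returns a number rather than a limit in this assay: the limit of > 400 ug/mL in this assay, at which 2 of the 4 values shown sit. On a saturated chain carbon bound to a saturated ring carbon, replacing 2,5-dioxopyrrolidin-1-yl with 1H-1,2,3-triazol-1-yl gives an at least 1.7-fold lower number from compound 3 to compound 4 (0.24 log units; that floor lies within the scatter), so this change points towards a lower number without establishing one. The same position also carries two very different groups, 1H-1,2,3-triazol-1-yl and 4-((methoxycarbonyl)methyl)piperidin-1-yl, with no separation between them, as shown by a 1.0-fold higher number from compound 1 to compound 4 (0.00 log units; within the scatter).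

Going by these compounds, since the value for compound 3 is only a limit, the full size of its step to compound 4 remains open. Also open, on these data alone, is how a primary amine, a carboxylic acid or a longer chain bearing the triazole would read at this place.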